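The source may report more compounds than this note shows. Statements on the series, on what has been measured and on what is new or still open speak of the compounds shown alone.

Measured so far in a functional assay on CHO cells for agonist activity at 5-hydroxytryptamine receptor 1D (Homo sapiens), read by GTPgammaS binding; on this read-out higher numbers stand for an effect only at larger amounts of compound and lower numbers for an effect already at smaller amounts:
- compound 1, `CN(Cc1ccccc1)CC1CCN(CCCc2c[nH]c3ccc(-n4cnnc4)cc23)CC1`: 0.9 nM
- compound 2, `CN(Cc1ccccc1)C1CCN(CCCc2c[nH]c3ccc(-n4cnnc4)cc23)CC1`: 1.6 nM
- compound 3, `c1ccc(CNC2CCN(CCCc3c[nH]c4ccc(-n5cnnc5)cc34)CC2)cc1`: 8 nM

All three share the same core and differ only in the amine side group. Compound 3 has the highest number of the three: the step of a 5.0-fold higher number from compound 2 to compound 3 (0.70 log units; beyond the scatter) and the step of an 8.9-fold higher number from compound 1 to compound 3 (0.95 log units; beyond the scatter) both lie beyond the scatter, while the step of a 1.8-fold higher number from compound 1 to compound 2 (0.25 log units; within the scatter) does not.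

Compound 4, `C[C@@H](NC1CCN(CCCc2c[nH]c3ccc(-n4cnnc4)cc23)CC1)c1ccccc1`, is compound 3 with one change: methyl in place of hydrogen on a saturated chain carbon bound to an amine nitrogen and an aromatic carbon. Going by the values given here, no measured step adds a methyl at this place. The nearest comparison is the step of a 5.0-fold higher number from compound 2 to compound 3 (0.70 log units; beyond the scatter), which concerns a methyl on the amine nitrogen rather than on the neighbouring chain carbon, so it bears on the new step only loosely. On that thin basis, the expected step of a 1.3-fold lower number from compound 3 to compound 4 (0.12 log units; within the scatter) in this assay is small and may stay within the scatter. For compound 4 the estimate is 6 nM, with a range from 1.5 nM to 25 nM.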

Compound 4, half-maximal effective concentration: 1.5 nM
Compound 4: the middle estimate sits 4.0-fold (0.60 log units) above what was measured; measured number inside the range.
By their numbers in this assay, from the lowest: compounds 1, 4 and 2 (each within the scatter of the next); then compound 3.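

In this assay, methyl on the saturated chain carbon bound to an amine nitrogen and an aromatic carbon lowers the number clearly (a 5.3-fold lower number from compound 3 to compound 4 (0.73 log units; beyond the scatter)), so a single added carbon at this place matters. Going by these compounds alone, this is a new site: the earlier compounds showed only that a methyl on the amine nitrogen goes with a lower number (a 5.0-fold higher number from compound 2 to compound 3 (0.70 log units; beyond the scatter)). With benzyl changed to 1-phenylethyl, compound 4 stands level with both compounds carrying that nitrogen methyl (a 1.1-fold lower number from compound 2 to compound 4 (0.03 log units; within the scatter); a 1.7-fold higher number from compound 1 to compound 4 (0.22 log units; within the scatter)), and no measurement shown explains this. Still open, on these data alone, is whether a larger group on this carbon, such as ethyl or hydroxymethyl, would lower the number further. Also open, as far as these compounds go, is whether the mirror-image form of compound 4 would behave the same way.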